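This account rests on a few compounds, and the source may have more. Where it says the series, first, only, none or still open, it means among the compounds named here.

In a functional assay on A549 cells (Homo sapiens) for inhibition, read by sulforhodamine B assay, with a stated time of 48 h (a lower number here means a stronger inhibitor of growth, a higher number a weaker inhibitor of growth), three compounds have so far been measured:

compound 1 `O=C(Nc1cccc(-n2cc(-c3ccncc3)c(-c3ccc(Cl)c(O)c3)n2)c1)Nc1cccc(C(F)(F)F)c1` with 1370 nM
compound 2 `COc1cc(-c2nn(-c3cccc(NC(=O)Nc4cc(C(F)(F)F)cc(C(F)(F)F)c4)c3)cc2-c2ccncc2)ccc1Cl` with 527 nM
compound 3 `COc1cc(-c2nn(-c3cccc(NC(=O)Nc4cccc(C(F)(F)F)c4)c3)cc2-c2ccncc2)ccc1Cl` with 794 nM

Compound 2 has the lowest number of the three. Its nearest neighbour is compound 3, and the step of a 1.5-fold higher number from compound 2 to compound 3 (0.18 log units; within the scatter) keeps the two within the scatter of one another, so no order can be read between them. Compound 1 is further away: its value and that of compound 2 are separated by more than the scatter, with compound 1 giving the higher number.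

Compound 4 `O=C(Nc1cccc(-n2cc(-c3ccncc3)c(-c3ccc(Cl)c(O)c3)n2)c1)Nc1cc(C(F)(F)F)cc(C(F)(F)F)c1` is the next compound in line. It differs from compound 2 in one place: hydrogen in place of methyl on an oxygen on an aromatic ring. Within the data shown here, the only measured step that bears on this change is the one between compound 1 and compound 3, which carries the same difference in the opposite direction: a 1.7-fold lower number from compound 1 to compound 3 (0.24 log units; within the scatter). That step stayed within the scatter. Reversing it, compound 4 is expected to sit a little above compound 2 in this assay, by a step of about a 1.7-fold higher number from compound 2 to compound 4 (0.23 log units; within the scatter), which may well not clear the scatter. The value expected for compound 4 is therefore 900 nM, with a range from 400 nM to 2000 nM.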

Compound 4, concentration for 50% growth inhibition: 298 nM
Beside the measured number, compound 4's estimate is 3.0-fold (0.48 log units) above it, and the stated range ends above it.
By their numbers in this assay, from the lowest: compounds 4, 2, 3 and 1 (each within the scatter of the next, the first and the last beyond it).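

In this assay, among these compounds, the change from methoxy to hydroxy with the second trifluoromethyl present gives a 1.8-fold lower number from compound 2 to compound 4 (0.25 log units; within the scatter), so no order can be read between these two compounds, yet the change does not carry over unaltered from one core to the other: the same change on two cores in this assay, a 1.7-fold lower number (0.24 log units; within the scatter) from compound 1 to compound 3 and a 1.8-fold higher number (0.25 log units; within the scatter) from compound 4 to compound 2, 3.1-fold (0.48 log units) apart, beyond the scatter of two such steps Adding the second trifluoromethyl to the hydroxy core gives a 4.6-fold lower number from compound 1 to compound 4 (0.66 log units; beyond the scatter), the first step of this change to clear the scatter, and it differs from the same change on the methoxy core: the same change on two cores in this assay, a 1.5-fold higher number (0.18 log units; within the scatter) from compound 2 to compound 3 and a 4.6-fold higher number (0.66 log units; beyond the scatter) from compound 4 to compound 1, 3.1-fold (0.48 log units) apart, beyond the scatter of two such steps Across these four compounds, then, the two places do not act independently, as what a change at one place does depends on the group at the other.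

Going by these compounds, whether an amine or an ethoxy in place of the hydroxy, or a nitrile in place of the added trifluoromethyl, would show the same dependence remains open. On these data alone, these four compounds also form a single set of two changes, so it is equally open whether the dependence extends to any other core.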